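Replacing the aryl group on the shared core

The source may hold more compounds than are shown below. What is called first, only, known or untested is meant among the compounds shown, and "the series" means these compounds.

Going by the values given here, compound 1 `O=C1O[C@H]([C@@H](O)Cn2cc(-c3cccc(O)c3)nn2)C(OCc2ccccc2)=C1OCc1ccccc1` is the only compound with a numerical value: in a functional assay on HCT-116 cells (Homo sapiens) for antiproliferative activity, read by MTT assay, with a stated time of 72 h (on this read-out higher numbers stand for weaker inhibition and lower numbers for stronger inhibition), compound 1 gives 42900 nM. Compound 2 `COc1ccccc1-c1cn(C[C@H](O)[C@H]2OC(=O)C(OCc3ccccc3)=C2OCc2ccccc2)nn1` reaches only the assay limit, > 100000 nM. Its value sits at the limit of > 100000 nM in this assay, at which 1 of the 2 values shown sits. The step of an at least 2.3-fold higher number from compound 1 to compound 2 (0.36 log units; beyond the scatter) shows that exchanging the aryl group already weakens inhibition. Compound 3 `O=C1O[C@H]([C@@H](O)Cn2cc(CCO)nn2)C(OCc2ccccc2)=C1OCc1ccccc1` differs from compound 1 by 2-hydroxyethyl in place of 3-hydroxyphenyl on an aromatic carbon. Among the compounds with values here, only the step from compound 1 to compound 2 bears on this change, and that step kept an aromatic ring. For compound 3 a step of at least that size toward weaker inhibition is expected, a 2.1-fold higher number from compound 1 to compound 3 (0.32 log units; beyond the scatter). Compound 3 is therefore expected near 90000 nM, between 40000 nM and 200000 nM, with a fair chance of only a limit.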

Compound 3, half-maximal inhibitory concentration: 72700 nM
Compound 3: the middle estimate sits 1.2-fold (0.09 log units) above what was measured; the measured number falls inside the stated range.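

In this assay the exchange of 3-hydroxyphenyl for 2-hydroxyethyl gives no separation (a 1.7-fold higher number from compound 1 to compound 3 (0.23 log units; within the scatter)), so on this carbon compound 3 keeps the level of compound 1 without an aromatic ring. The comparison with the 2-methoxyphenyl compound sets no firm order (an at least 1.3-fold lower number from compound 2 to compound 3 (0.13 log units; that floor lies within the scatter)). Compound 2 stands only as a limit: the limit of > 100000 nM in this assay, at which 1 of the 3 values shown sits.

Open, on these data alone, is whether an amine, a carboxylic acid or a longer chain on this carbon would give a clearly lower number. Also open, as far as these compounds go, is how plain phenyl would compare with 3-hydroxyphenyl.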